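The source may report more compounds than this note shows. Statements on the series, on what has been measured and on what is new or still open speak of the compounds shown alone.

The study holds two measured compounds, compound 1 `Cc1ccc([C@@H](C)Oc2cc3onc(CCC(=O)O)c3cc2Cl)nc1` and compound 2 `CCOc1cc2oc(=O)n(CCC(=O)O)c2cc1Cl`, and one not yet measured, compound 3 `C[C@@H](Oc1cc2onc(CCC(=O)O)c2cc1Cl)c1ccccn1`. In a physicochemical assay for pharmacokinetics, at pH 6 (a lower number here means that the compound disappears faster, a higher number that the compound lasts longer), compound 1 gives > 1000 h, which is a limit of the assay and not a number. In this assay compound 2 likewise gives > 1000 h, also a limit. Both values therefore sit at the limit of > 1000 h in this assay, at which 2 of the 2 values shown sit. Compound 3 differs from compound 1 by hydrogen in place of methyl on an aromatic carbon. No step between measured compounds is shown, so the step that the limit leaves unreadable from compound 1 to compound 3 is expected to be none beyond the scatter. Compound 3 is estimated at 1500 h, between 700 h and 5000 h.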

Compound 3, half-life: > 1000 h
Compound 3 was reported as a limit; the forecaster's own chance of this, stated with the estimate: 85%; the middle value lies beyond the limit too.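

In this assay, for the compounds shown here, compound 1 and compound 3 both stand at a limit, so no step between them can be read: the limit of > 1000 h in this assay, at which 3 of the 3 values shown sit. The compounds shown leave open how long any of them lasts in this assay and whether swapping methyl for hydrogen changes it at all.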